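The compounds below may be only part of what the source reports. "The series", "measured", "known", "first", "only" and "open" are said of these compounds alone.

Measured so far in an ADME assay on L02 cells (Homo sapiens) for cytotoxicity, read by MTT assay; a higher number here means a weaker inhibitor, a lower number a stronger inhibitor:
- Compound 1 `COc1ccc(/C=C/C(=O)c2ccc(OC)c3c2OC(C)(C)C=C3)cc1OCC=C(C)C`: > 10000 nM, a limit of the assay
- Compound 2 `COc1ccc(/C=C/C(=O)c2ccc(OC)c3c2OC(C)(C)C=C3)cc1OC(=O)C(C)C`: > 10000 nM, a limit of the assay
- Compound 3 `COc1ccc(/C=C/C(=O)c2ccc(OC)c3c2OC(C)(C)C=C3)cc1OC(=O)c1ccc(Br)cc1`: 8400 nM

For the measured compounds named here, compound 3 carries the only real number, and the rest of the series stands at the limit of > 10000 nM in this assay, at which 2 of the 3 values shown sit.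

Compound 4 `COc1ccc(/C=C/C(=O)c2ccc(OC)c3c2OC(C)(C)C=C3)cc1OC(=O)c1ccco1` has furan-2-yl in place of 4-bromophenyl on a carbonyl carbon.

Two measured steps end at compound 3 and bear on this change: an at least 1.1-fold lower number from compound 2 to compound 3 (0.07 log units; that floor lies within the scatter), and an at least 1.1-fold lower number from compound 1 to compound 3 (0.07 log units; that floor lies within the scatter). Both are only floors, so neither gives a firm size. No clear direction can be expected either. The expected step is none beyond the scatter: a 1.1-fold higher number from compound 3 to compound 4 (0.05 log units; within the scatter). For compound 4 the estimated value is 9500 nM, with an expected range of 5000 nM to 18000 nM.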

Compound 4, half-maximal inhibitory concentration: > 10000 nM
Compound 4: only a limit was reported (the forecaster's own chance of this, stated with the estimate: 45%); middle value at least 1.0-fold (0.02 log units) away from the limit.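

Putting furan-2-yl in place of 4-bromophenyl on this carbonyl carbon gives an at least 1.1-fold higher number from compound 3 to compound 4 (0.07 log units; that floor lies within the scatter) in this assay, so the change shows no step beyond the scatter, only a floor. From the compounds shown here alone, compound 4 gives only a limit of the assay, so the true size of this step stays unknown, and the steps to it from compound 1 and compound 2 cannot be read. Compound 3 remains the only compound with a real number, and most of the series now sits at one value: the limit of > 10000 nM in this assay, at which 3 of the 4 values shown sit.

The compounds shown leave open what a chain ending in an amine or a carboxylic acid would give on an oxygen on an aromatic ring.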